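From Ethyl Ester to Free Acid: Expected Cytotoxicity

This account rests on a few compounds, and the source may have more. Where it says the series, first, only, none or still open, it means among the compounds named here.

Compound 1, `O=S(=O)(Nc1cccc(CO)c1)c1ccc(-c2ccc3[nH]ccc3c2)cc1`, in a functional assay on J774 cells (Mus musculus) for cytotoxicity, read by resazurin assay, with a stated time of 72 h; a lower number here means a stronger inhibitor, a higher number a weaker inhibitor: > 5000 nM, a limit of the assay (the limit of > 5000 nM in this assay, at which 1 of the 3 values shown sits).
Compound 2, `O=S(=O)(Nc1cccc(CO)c1)c1ccc(-c2ccc3cc[nH]c3c2)cc1`: 2500 nM.
Compound 3, `CCOC(=O)c1cccc(NS(=O)(=O)c2ccc(-c3ccc(Cl)cc3Cl)cc2)c1`: 20000 nM.

Among the compounds with values here, the one step measured between single-point neighbours is an at least 2.0-fold lower number from compound 1 to compound 2 (0.30 log units; that floor lies within the scatter), and it concerns the swap of one fused ring attachment for another, not the ester side of the molecule. Compound 3 stands at the highest of the two numbers that are actual values; its nearest neighbour is compound 2, whose number lies well below it, and the gap between the two is beyond the scatter. Compound 4, `O=C(O)c1cccc(NS(=O)(=O)c2ccc(-c3ccc(Cl)cc3Cl)cc2)c1`, differs from compound 3 by hydrogen in place of ethyl on an oxygen next to a carbonyl group. Within the data shown here, no measured step touches this position, so nothing among the measured pairs speaks for a change in either direction. With compound 3 already at the weak end, the expected outcome is a step of a 1.3-fold higher number from compound 3 to compound 4 (0.10 log units; within the scatter), within the scatter, with a real chance that the assay returns only a limit. Compound 4 is therefore estimated at 25000 nM, with a likely range from 8000 nM to 80000 nM.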

Compound 4, half-maximal inhibitory concentration: > 50000 nM
Compound 4: a limit, no number (the forecaster's own chance of this, stated with the estimate: 35%); middle value at least 2.0-fold (0.30 log units) away from the limit.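

Hydrogen in place of ethyl on an oxygen next to a carbonyl group gives, in this assay, an at least 2.5-fold higher number from compound 3 to compound 4 (0.39 log units; beyond the scatter), the first measured evidence that this position matters for the read-out. Within the data shown here, compound 4 gives > 50000 nM, which is a limit of the assay and not a number: the limit of > 50000 nM in this assay, at which 1 of the 4 values shown sits. The step is therefore only a floor on the change from ethoxycarbonyl to carboxy, yet even that floor lies beyond the scatter, whereas the only earlier step, an at least 2.0-fold lower number from compound 1 to compound 2 (0.30 log units; that floor lies within the scatter), concerned the swap of 1H-indol-5-yl for 1H-indol-6-yl and said nothing about this position.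

The compounds shown leave open how far the number of compound 4 actually lies from that of compound 3, and whether the same change would shift the number in the same direction on a core other than that of compound 3. They also leave open how the number would respond if the ethoxy of compound 3 were replaced by a longer chain such as butoxy, or by an amine that turns the ester into an amide.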